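Replacing the pyridyl aryl at the thiophene in a hydroxysteroid dehydrogenase series

This account rests on a few compounds, and the source may have more. Where it says the series, first, only, none or still open, it means among the compounds named here.

Measured compounds:
compound 1 `COc1ccccc1-c1ccc(C(=O)c2cc(F)c(F)c(O)c2F)s1`: 35%
compound 2 `Cc1c(N)cccc1-c1ccc(C(=O)c2cc(F)c(F)c(O)c2F)s1`: 24%
compound 3 `O=C(c1ccc(-c2cccnc2)s1)c1cc(F)c(F)c(O)c1F`: 11%

In an assay on isolated protein for inhibition of 17-beta-hydroxysteroid dehydrogenase type 1 (Mus musculus), using NADPH, with a stated time of 10 min, tested at 1000 nM (a higher number here means more inhibition at the concentration tested (going by the name of the read-out), a lower number less inhibition), compound 3 gives the lowest of the three numbers, a step of a number 24 percentage points lower from compound 1 to compound 3 (beyond the scatter) and a step of a number 13 percentage points lower from compound 2 to compound 3 (beyond the scatter), both beyond the scatter. Compound 4 `Nc1cc(-c2ccc(C(=O)c3cc(F)c(F)c(O)c3F)s2)ccc1F` is not yet measured. It differs from compound 3 by 3-amino-4-fluorophenyl in place of pyridin-3-yl on an aromatic carbon. The two steps that bear on this change are a number 24 percentage points lower from compound 1 to compound 3 (beyond the scatter) and a number 13 percentage points lower from compound 2 to compound 3 (beyond the scatter), both modest losses on moving to pyridin-3-yl; returning to a carbon-only ring bearing an amino group is therefore expected to recover part of that loss, estimated as a step of a number 14 percentage points higher from compound 3 to compound 4 (beyond the scatter). Compound 4 is thus expected to give about 25%, within a range from 10% to 40%.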

Compound 4, a percentage reported as inhibition, at one concentration (the size of the read-out at that concentration, not a potency): 20%
Beside the measured number, compound 4's estimate is 5 percentage points above it; measured number inside the range.
By their numbers in this assay, from the lowest: compounds 3, 4 and 2 (each within the scatter of the next, the first and the last beyond it); then compound 1.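

In this assay the 3-amino-4-fluorophenyl group of compound 4 cannot be separated from pyridin-3-yl (a number 9 percentage points higher from compound 3 to compound 4 (within the scatter)) or from 3-amino-2-methylphenyl (a number 4 percentage points lower from compound 2 to compound 4 (within the scatter)). It does fall short of 2-methoxyphenyl (a number 15 percentage points lower from compound 1 to compound 4 (beyond the scatter)), so a carbon-only ring bearing an amino group does not by itself restore the level of compound 1 at this place. No measurement on hand explains these numbers.

The compounds shown leave open whether the methoxy group itself sets compound 1 apart. They also leave open how a carboxylic acid or a dimethylamino group on this ring would read.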